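Isopropyl in Place of Phenyl, Starting From a Limit

The source may hold more compounds than are shown below. What is called first, only, known or untested is meant among the compounds shown, and "the series" means these compounds.

Three compounds have so far been examined in a functional assay on MIA PaCa-2 cells (Homo sapiens) for inhibition; a higher number here means a weaker inhibitor, a lower number a stronger inhibitor. Compound 1 `CCC(C)C(NC(=O)n1nnc2ccccc21)C(=O)NCc1ccccc1` gives > 100000 nM, which is a limit of the assay and not a number. Compound 2 `O=C1NC(c2ccccc2)C(=O)N1C1CCCC1` likewise gives only a limit, > 100000 nM. Compound 3 `CC(C)C1NC(=O)N(C2CCCCC2)C1=O` also returns a limit, > 100000 nM. Within the data shown here, compound 2 therefore stands at the limit of > 100000 nM in this assay, at which 3 of the 3 values shown sit, and no measured number places it among the others, so no step between measured compounds can be drawn in this assay.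

The unmeasured compound 4 `CC(C)C1NC(=O)N(C2CCCC2)C1=O` differs from compound 2 by isopropyl in place of phenyl on a saturated ring carbon. With nothing quantified, the measurements give no direction for this change; the three limits only show that neither compound 2 nor compound 3, which already carries an isopropyl on the same kind of ring carbon, produced a number in this assay.

Compound 4 is accordingly expected to sit at about 150000 nM, between 50000 nM and 500000 nM, most likely as a limit rather than a number once more. The expected change a step that the limit leaves unreadable from compound 2 to compound 4 is thus none beyond the scatter.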

Compound 4, half-maximal inhibitory concentration: > 100000 nM
Compound 4: no number, only a limit; the forecaster's own chance of this, stated with the estimate: 85%; the middle value does not contradict the limit.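

Compound 4 gives > 100000 nM, a limit of the assay and not a number. Among these compounds, with compound 2 also standing only at a limit, no step between compound 2 and compound 4 can be read. The compounds shown leave open whether isopropyl in place of phenyl on a saturated ring carbon changes inhibition in this assay at all.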